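This account rests on a few compounds, and the source may have more. Where it says the series, first, only, none or still open, it means among the compounds named here.

In a functional assay (aorta) with Oryctolagus cuniculus as the target (on this read-out lower numbers stand for tighter binding and higher numbers for weaker binding), compound 1 (`COc1cc(C(C)=O)ccc1OCCCN1CCC(C(c2ccc(F)cc2)c2ccc(F)cc2)CC1`) gives 1.59 nM and compound 2 (`CCc1ccc(OCCCN2CCC(C(c3ccc(F)cc3)c3ccc(F)cc3)CC2)c(OC)c1`) gives 2.51 nM in the same read-out. These two are not separated, with a 1.6-fold higher number from compound 1 to compound 2 (0.20 log units; within the scatter) in this comparison. Compound 3 (`NC(=O)c1ccc(OCCCN2CCC(C(c3ccc(F)cc3)c3ccc(F)cc3)CC2)cc1`) stands highest of the three at 31.6 nM on this scale. Large steps lead there, a 20-fold higher number from compound 1 to compound 3 (1.30 log units; beyond the scatter) and a 13-fold higher number from compound 2 to compound 3 (1.10 log units; beyond the scatter) as measured.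

Compound 4 (`Fc1ccc(C(c2ccc(F)cc2)C2CCN(CCCOc3ccc(Br)cc3)CC2)cc1`) carries bromo in place of carbamoyl on an aromatic carbon, para to a large group (bromo in place of carbamoyl on an aromatic carbon). The two large steps are the ones that bear on this change, but each also removes the methoxy group, so neither isolates the carbamoyl. Among the compounds with values here, no measured compound carries bromo. Compound 4 is therefore expected to recover only part of those steps in this assay and, as it also lacks the methoxy group, to keep a higher number than compound 2, which gives 2.51 nM on this scale. The expected move is a 3.2-fold lower number from compound 3 to compound 4 (0.50 log units; beyond the scatter) towards a lower number. Compound 4 is estimated at 10 nM with an expected range from 3 nM to 30 nM in this read-out.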

Compound 4, dissociation constant: 1.59 nM
Compound 4: middle estimate off by 6.3-fold (0.80 log units), on the high side; the whole stated range lies above it.
By their numbers in this assay, from the lowest: compounds 1, 4 and 2 (each within the scatter of the next); then compound 3.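

In this assay, within the data shown here, the change from carbamoyl to bromo at this aromatic carbon is large (a 20-fold lower number from compound 3 to compound 4 (1.30 log units; beyond the scatter)), which isolates the group effect better than the earlier steps could. Compound 4 has no methoxy group, yet it is not separated from compound 2 (a 1.6-fold lower number from compound 2 to compound 4 (0.20 log units; within the scatter)) or from compound 1 (no change at the digits printed from compound 1 to compound 4 (within the scatter)), so among these four compounds the missing methoxy group does not by itself go with a high number, and only compound 3, the one carrying carbamoyl, stands apart. Nothing available here explains why carbamoyl and bromo differ so widely.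

The compounds shown leave open whether an amine, a carboxylic acid or chloro at this place would fall with compound 3 or with compound 4. They also leave open what bromo and methoxy would give together on the same ring.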